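The source may hold more compounds than are shown below. What is called first, only, known or untested is meant among the compounds shown, and "the series" means these compounds.

The series rests on a shared core carrying a methylpyrrolidine, a nitrile and an aminopyrimidine, differing only in the pyrazole hung from the ring nitrogen. Compound 1 `C[C@@H]1CCCN1c1c(C#N)c2c(N)nc(Nc3cn[nH]c3)nc2n1C` gives 6 nM in an assay on isolated protein for inhibition of Leucine-rich repeat serine/threonine-protein kinase 2 variant G2019S (Homo sapiens), read by TR-FRET and LanthaScreen, with stated times of 50 min and 30 min, in the presence of a further agent that is not named here; a lower number here means a stronger inhibitor, a higher number a weaker inhibitor. Compound 2 `C[C@@H]1CCCN1c1c(C#N)c2c(N)nc(Nc3cn(C)nc3Cl)nc2n1C` gives 21 nM, and compound 3 `Cc1nn(C)cc1Nc1nc(N)c2c(C#N)c(N3CCC[C@H]3C)n(C)c2n1` gives 30 nM. Compound 3 thus holds the highest of the three numbers; its nearest neighbour is compound 2, as the step of a 1.4-fold higher number from compound 2 to compound 3 (0.15 log units; within the scatter) shows, while its distance from compound 1 is given by a 5.0-fold higher number from compound 1 to compound 3 (0.70 log units; beyond the scatter).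

Compound 4 `C[C@@H]1CCCN1c1c(C#N)c2c(N)nc(Nc3cn(C)nc3C(F)(F)F)nc2n1C` differs from compound 3 by trifluoromethyl in place of methyl on an aromatic carbon. The step that bears most directly on this swap at the same aromatic carbon is a 1.4-fold higher number from compound 2 to compound 3 (0.15 log units; within the scatter), which stayed within the scatter. The steps of a 3.5-fold higher number from compound 1 to compound 2 (0.54 log units; beyond the scatter) and a 5.0-fold higher number from compound 1 to compound 3 (0.70 log units; beyond the scatter) show that decorating the pyrazole raised the number only modestly. The expectation for compound 4 in this assay is therefore a step no larger than the scatter, a 1.2-fold higher number from compound 3 to compound 4 (0.07 log units; within the scatter). Compound 4 is estimated at 35 nM, expected between 15 nM and 85 nM.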

Compound 4, half-maximal inhibitory concentration: 358 nM
Compound 4: the middle estimate sits 10-fold (1.01 log units) below what was measured; the measured number lies above the stated range.
By their numbers in this assay, from the lowest: compound 1; then compounds 2 and 3 (each within the scatter of the next); then compound 4.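

Chloro and methyl had been indistinguishable at this aromatic carbon of the pyrazole, but the position does not accept every group equally. In this assay trifluoromethyl gives a 12-fold higher number from compound 3 to compound 4 (1.08 log units; beyond the scatter) and also a 17-fold higher number from compound 2 to compound 4 (1.23 log units; beyond the scatter) as measured against chloro. The whole change of the pyrazole amounts to a 60-fold higher number from compound 1 to compound 4 (1.78 log units; beyond the scatter) in the same assay, so the identity of the group on this carbon, and not merely the presence of one, sets the size of the step, and the data shown offer no account of why trifluoromethyl parts from the other two.

From the compounds shown here alone, it remains open whether a difluoromethyl or an ethyl group on this carbon would track with chloro and methyl or with trifluoromethyl. Also open is what share the 1-methyl group has in these steps, as every decorated pyrazole shown carries it.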